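A few compounds are considered here, and "the series" means these few. Any claim that something is new, unique, unknown or untested is made for them only; others in the source may bear on it.

Measured so far in an in vitro ADME assay on microsomes (Rattus norvegicus) for metabolic stability; on this read-out higher numbers stand for a longer-lived compound and lower numbers for a shorter-lived compound:

- compound 1 `CCc1nc(-c2ccc(Cl)cc2Cl)c(CC)nc1NC(COC)COC`: 0.0417 h
- compound 2 `CCOc1nc(-c2ccc(Cl)cc2Cl)c(CC)nc1NC(CC)CC`: 1.23 h

Of these two numbers, compound 1 holds the lower one, at 0.0417 h, and compound 2 stands at 1.23 h, a gap that lies well beyond the scatter of repeated measurements. Compound 1 is therefore the shorter-lived of the pair.

The next compound to be tested is compound 3 `CCc1nc(-c2ccc(Cl)cc2Cl)c(CC)nc1NC(C1CC1)C1CC1`. It keeps the core of compound 1 and changes one group, on a nitrogen on an aromatic ring: dicyclopropylmethyl takes the place of 2-methoxy-1-(methoxymethyl)ethyl (dicyclopropylmethyl in place of 2-methoxy-1-(methoxymethyl)ethyl on a nitrogen on an aromatic ring). For the measured compounds named here, no measured pair shows what this swap does on its own, so any forecast is a judgement. Going by the values given here, compound 2, at 1.23 h, shows only that a related compound can last far longer in this assay than compound 1 does.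

A rise beyond the scatter is expected, with the estimated step being a 4.8-fold higher number from compound 1 to compound 3 (0.68 log units; beyond the scatter). For compound 3 the estimated half-life is 0.2 h, with an expected range from 0.05 h to 0.9 h.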

Compound 3, half-life: 0.0417 h
Estimate against measurement, compound 3: 4.8-fold (0.68 log units) above, and the stated range ends above it.
By their numbers in this assay, from the lowest: compounds 1 and 3 (each within the scatter of the next); then compound 2.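

In this assay, placing dicyclopropylmethyl where 2-methoxy-1-(methoxymethyl)ethyl stood, on a nitrogen on an aromatic ring, gives no change at the digits printed from compound 1 to compound 3 (within the scatter). For the compounds shown here, this is the first pair that differs in one place only, so it is the first direct reading of this position: an ether-bearing open chain and a group built from three-membered carbon rings, each with the same number of heavy atoms, cannot be told apart by this half-life. No measurement shown here bears on why the two groups read alike.

Compound 2 differs from compound 1 in more than one place, so the contrast between their numbers cannot be assigned to the group on the nitrogen or to any other single part of the structure. From the compounds shown here alone, it also remains open whether any group on this nitrogen would separate from these two, for example a cyclobutyl ring, a chain ending in a hydroxyl group or a longer carbon chain, or whether a change elsewhere on the shared core is needed to shift the half-life.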